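Nitro Substitution on Two Benzimidazole-Bearing Cores

The source may hold more compounds than are shown below. What is called first, only, known or untested is meant among the compounds shown, and "the series" means these compounds.

The study compares two small series in a functional assay on HepG2 cells (Homo sapiens) for cytotoxicity, read by MTT assay; a higher number here means a weaker inhibitor, a lower number a stronger inhibitor. Compound 1 `COc1ccc2c(c1)CCC/C2=N\NCc1nc2ccccc2[nH]1` gives 80000 nM in this assay. Compound 3 `COc1ccc2c(c1)CCC/C2=N\NCc1nc2cc([N+](=O)[O-])ccc2[nH]1` carries nitro in place of hydrogen on an aromatic carbon and gives 96000 nM in this assay; the resulting step is a 1.2-fold higher number from compound 1 to compound 3 (0.08 log units; within the scatter). Compound 2 `CC1=NN(Cc2nc3ccccc3[nH]2)C(=O)C1` rests on a different core; how its core differs from that of compound 1 is not broken down here. In this assay compound 2 gives 54000 nM, and its values and those of compound 1 and compound 3 all lie within the usual scatter of one another, so no order among the three can be read from them.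

Compound 4 `CC1=NN(Cc2nc3cc([N+](=O)[O-])ccc3[nH]2)C(=O)C1` has not yet been measured. It relates to compound 2 by nitro in place of hydrogen on an aromatic carbon, the same change, at the same described place, as that from compound 1 to compound 3. Because the measured instance of this change gave a 1.2-fold higher number from compound 1 to compound 3 (0.08 log units; within the scatter), the step from compound 2 to compound 4 is expected to be a 1.2-fold higher number from compound 2 to compound 4 (0.08 log units; within the scatter). On that basis compound 4 is estimated to give 65000 nM in this assay, most likely between 30000 nM and 140000 nM.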

Compound 4, half-maximal inhibitory concentration: 265000 nM
For compound 4 the middle estimate is 4.1-fold (0.61 log units) below the measured one, and the stated range ends below it.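

In this assay, nitro in place of hydrogen on an aromatic carbon gives a 4.9-fold higher number from compound 2 to compound 4 (0.69 log units; beyond the scatter), so on the core of compound 2 the change moves the number beyond the scatter. Set beside the earlier step, the same change did not carry over at the same size from one core to the other: the same change on two cores in this assay, a 1.2-fold higher number (0.08 log units; within the scatter) from compound 1 to compound 3 and a 4.9-fold higher number (0.69 log units; beyond the scatter) from compound 2 to compound 4, 4.1-fold (0.61 log units) apart, beyond the scatter of two such steps. This shows that, for these two pairs, the size of the step cannot be taken from one core to the other, but it does not show which difference between the cores goes with the gap or how the change would behave on a third core.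

The compounds shown carry only hydrogen or nitro at this place, which leaves open whether an amine or a carboxylic acid there would give a step close to the smaller one, close to the larger one, or unlike either. On these data alone, it also remains open whether any such group would give steps that differ between the two cores as the nitro steps do.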